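This account rests on a few compounds, and the source may have more. Where it says the series, first, only, none or still open, it means among the compounds named here.

Values in an ADME assay on HEK293 cells (Homo sapiens) for cytotoxicity, read by MTT assay, with a stated time of 48 h; on this read-out higher numbers stand for weaker inhibition and lower numbers for stronger inhibition:
- compound 1 `COc1ccc(-c2nc(SCC(=O)c3sc(-c4ccccc4)nc3C)[nH]c(=O)c2C#N)cc1`: 76200 nM
- compound 2 `COc1ccc(-c2nc(C)c(C(=O)CSc3nc(-c4ccc(Cl)cc4)c(C#N)c(=O)[nH]3)s2)cc1`: 63000 nM
- compound 3 `COc1ccc(-c2nc(SCC(=O)c3sc(-c4ccc(Cl)cc4)nc3C)[nH]c(=O)c2C#N)cc1`: "not determined" (no result reported)

Compound 3 has no number, so the step below has no measured starting point. Still to be measured is compound 4 `Cc1nc(-c2ccc(Cl)cc2)sc1C(=O)CSc1nc(-c2ccc(Cl)cc2)c(C#N)c(=O)[nH]1`. The change is chloro in place of methoxy on an aromatic carbon, 4-methoxyphenyl to 4-chlorophenyl, with chloro in place of methoxy on an aromatic carbon. Compound 1 at 76200 nM and compound 2 at 63000 nM lie within the usual scatter of each other, though they differ in more than one place. On that basis, no step beyond the scatter is expected in this assay, and no direction can be assigned. For compound 4 the expected value is 62000 nM, with an estimated range of 28000 nM to 130000 nM.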

Compound 4, half-maximal inhibitory concentration: 75100 nM
Compound 4: the middle estimate sits 1.2-fold (0.08 log units) below what was measured; the measured number falls inside the stated range.
By their numbers in this assay, from the lowest: compounds 2, 4 and 1 (each within the scatter of the next).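

In this assay, for the compounds shown here, the change from 4-methoxyphenyl to 4-chlorophenyl gives a 1.2-fold higher number from compound 2 to compound 4 (0.08 log units; within the scatter), the first comparison that differs in one place only, and at this position chloro and methoxy cannot be told apart on this read-out. Compound 3 has no number, so its step to compound 4 cannot be read. Nothing available bears on a cause for this result.

Going by these compounds, how an amine or a carboxylic acid on this aromatic carbon would read stays open. Also open, on these data alone, is whether a longer chain such as butoxy in place of methoxy would stay within the same scatter.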